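Removing a Hydroxy Group: Expected Half-life of Compound 4

The source may report more compounds than this note shows. Statements on the series, on what has been measured and on what is new or still open speak of the compounds shown alone.

Measured so far in an in vivo ADME assay on the whole organism for metabolic stability, with Canis familiaris (Canis lupus familiaris) as the target; a higher number here means that the compound lasts longer, a lower number that the compound disappears faster:
- compound 1, `Nc1noc2ccc(-n3nc(C(F)(F)F)c4c3C(=O)N(c3ccc(-c5ccccc5CN5CCCC5)cc3)CC4)cc12`, gives 5.3 h
- compound 2, `Nc1noc2ccc(-n3nc(C(F)(F)F)c4c3C(=O)N(c3ccc(-c5ccccc5CN5CC[C@@H](O)C5)cc3F)CC4)cc12`, gives 5.9 h
- compound 3, `CN(C)Cc1ccccc1-c1ccc(N2CCc3c(C(F)(F)F)nn(-c4ccc5onc(N)c5c4)c3C2=O)cc1`, gives 3.8 h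

Compound 2 gives the highest of these three numbers, yet its gaps to compound 1 and to compound 3 both lie within the usual scatter, so the three compounds cannot be told apart. Compound 4, `Nc1noc2ccc(-n3nc(C(F)(F)F)c4c3C(=O)N(c3ccc(-c5ccccc5CN5CCCC5)cc3F)CC4)cc12`, differs from compound 2 by hydrogen in place of hydroxy on a saturated ring carbon. Among the measured compounds shown here, the only measured single-point step, a 1.4-fold lower number from compound 1 to compound 3 (0.14 log units; within the scatter), changes the amine rather than a hydroxy group and so does not bear directly on this change; no measured pair shows what removing the hydroxy does. With the three values so close, compound 4 is expected to fall in the same region, with a 1.1-fold lower number from compound 2 to compound 4 (0.03 log units; within the scatter) and an estimated 5.5 h, ranging from 3.5 h to 9 h.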

Compound 4, half-life: 4.9 h
Compound 4: the middle estimate sits 1.1-fold (0.05 log units) above what was measured; the range from low to high includes it.
By their numbers in this assay, from the lowest: compounds 3, 4, 1 and 2 (each within the scatter of the next).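

In this assay removing the hydroxy gives a 1.2-fold lower number from compound 2 to compound 4 (0.08 log units; within the scatter) and so the 3-hydroxypyrrolidin-1-yl and pyrrolidin-1-yl groups cannot be told apart at this position. The fluoro on the aromatic carbon can now be read as well, with a 1.1-fold lower number from compound 1 to compound 4 (0.03 log units; within the scatter) and again no difference beyond the scatter. No measurement here accounts for either step.

On these data alone, whether a methoxy or an amine on this saturated ring carbon would move the half-life beyond the scatter remains open.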